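Moving the amino group on a thiazolidinedione benzylidene

The source may report more compounds than this note shows. Statements on the series, on what has been measured and on what is new or still open speak of the compounds shown alone.

Measured so far:
compound 1, `Nc1cccc(/C=C2\SC(=O)N(Cc3ccc(F)cc3)C2=O)c1`: 142000 nM
compound 2, `CC(C)(C)c1ccc(CN2C(=O)S/C(=C\c3cccc(N)c3)C2=O)cc1`: 223000 nM

Both numbers come from a functional assay on L1210 cells (Mus musculus) for cytotoxicity, read by cell counting, with a stated time of 2 days; a higher number here means a weaker inhibitor, a lower number a stronger inhibitor. Compound 1 and compound 2 share a core and differ only in the group on the benzyl ring; the step of a 1.6-fold higher number from compound 1 to compound 2 (0.20 log units; within the scatter) is small, so the two compounds stand together, neither separated from the other by more than the scatter, and compound 1 has no partner beyond that.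

Compound 3, `Nc1ccc(/C=C2\SC(=O)N(Cc3ccc(F)cc3)C2=O)cc1`, is built from compound 1 by a change at the other end of the molecule: 4-aminophenyl in place of 3-aminophenyl on a double-bonded chain carbon bound to a double-bonded ring carbon. Among the measured compounds shown here, no measured pair mirrors this change; the one step on record, a 1.6-fold higher number from compound 1 to compound 2 (0.20 log units; within the scatter), concerns a different position and says nothing about moving the amino group. With nothing to push the number either way, compound 3 is expected to stay near compound 1, a step of a 1.1-fold higher number from compound 1 to compound 3 (0.02 log units; within the scatter), so the estimate for compound 3 in this assay is 150000 nM, within 50000 nM to 450000 nM.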

Compound 3, half-maximal inhibitory concentration: 24000 nM
Compound 3: middle estimate off by 6.3-fold (0.80 log units), on the high side; measured number below the stated range.
By their numbers in this assay, from the lowest: compound 3; then compounds 1 and 2 (each within the scatter of the next).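

Where the amino group sits on the aromatic ring matters in this assay: 4-aminophenyl in place of 3-aminophenyl gives a 5.9-fold lower number from compound 1 to compound 3 (0.77 log units; beyond the scatter) even though the two groups have the same heavy atoms and the same counts of hydrogen-bond donors and acceptors. Among the compounds shown, this is the only step beyond the scatter, whereas the change on the benzyl ring gives a 1.6-fold higher number from compound 1 to compound 2 (0.20 log units; within the scatter) and leaves those two compounds together. No measurement at hand explains why moving the amino group lowers the number.

Still open, from the compounds shown here alone, is whether 4-aminophenyl would give a similarly lower number when tert-butyl replaces fluoro on the benzyl ring. It is also unknown whether the amino group itself matters, something that a hydroxyl group or a dimethylamino group in its place could test.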